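This account rests on a few compounds, and the source may have more. Where it says the series, first, only, none or still open, it means among the compounds named here.

Among the compounds with values here, in a toxicity assay on MT2 cells (Homo sapiens) for cytotoxicity, read by XTT assay, with a stated time of 4 days (on this read-out lower numbers stand for higher toxicity in this test and higher numbers for lower toxicity in this test), compound 1 `Cc1ccc(-c2ccc(C(=O)N[C@@H](c3nc(C)c(CO)s3)[C@@H]3CCCCN3)[nH]2)cc1F` gives 28200 nM and compound 2 `Cc1ccc(-c2ccc(C(=O)N[C@@H](c3nc(C)c(CCO)s3)[C@@H]3CCCCN3)[nH]2)cc1F` gives 21200 nM, so compound 2 stands within the scatter of its only measured neighbour. Compound 3 `Cc1ccc(-c2ccc(C(=O)N[C@@H](c3nc(C)c(CCCO)s3)[C@@H]3CCCCN3)[nH]2)cc1F` changes one place: hydroxymethyl in place of hydroxy on a saturated chain carbon, two bonds along the chain from an aromatic carbon. This turns 2-hydroxyethyl into 3-hydroxypropyl. Within the data shown here, the single measured step of the same kind, a 1.3-fold lower number from compound 1 to compound 2 (0.12 log units; within the scatter), stayed within the scatter, so no step beyond the scatter, in either direction, is expected in this assay. The expected step is a 1.1-fold lower number from compound 2 to compound 3 (0.03 log units; within the scatter). For compound 3 the estimated value is 20000 nM, with an expected range of 9000 nM to 40000 nM.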

Compound 3, half-maximal cytotoxic concentration: 20600 nM
Compound 3: middle estimate off by 1.0-fold (0.01 log units), on the low side; measured number inside the range.
By their numbers in this assay, from the lowest: compounds 3, 2 and 1 (each within the scatter of the next).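

In this assay, the change from 2-hydroxyethyl to 3-hydroxypropyl gives a 1.0-fold lower number from compound 2 to compound 3 (0.01 log units; within the scatter) and the two chain extensions taken together give a 1.4-fold lower number from compound 1 to compound 3 (0.14 log units; within the scatter) over the whole span. So a second extension at this place also stays within the scatter, and even the summed change from hydroxymethyl to 3-hydroxypropyl does not leave it. No measurement here offers an explanation for this. Still open, from the compounds shown here alone, is whether an amine or a carboxylic acid in place of the hydroxy, or a longer chain, would move the number beyond the scatter.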